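Cytotoxicity of a bromo analogue in a chalcone series

This account rests on a few compounds, and the source may have more. Where it says the series, first, only, none or still open, it means among the compounds named here.

The measured compounds and their numbers:
compound 1 `COc1ccc(/C=C/C(=O)c2c(C)[n+]([O-])c3ccccc3[n+]2[O-])cc1` gives 92000 nM;
compound 2 `Cc1c(C(=O)/C=C/c2ccc(Cl)cc2)[n+]([O-])c2ccccc2[n+]1[O-]` gives 21000 nM;
compound 3 `Cc1ccc(/C=C/C(=O)c2c(C)[n+]([O-])c3ccccc3[n+]2[O-])cc1` gives 40000 nM.

In an ADME assay on HPC cells (Homo sapiens) for cytotoxicity, with a stated time of 48 h (a higher number here means that more compound is tolerated, a lower number that less compound is tolerated), compound 3 stands second highest of the three numbers. Its nearest neighbour is compound 2, and a 1.9-fold higher number from compound 2 to compound 3 (0.28 log units; within the scatter) lies within the scatter. Its furthest is compound 1, and a 2.3-fold lower number from compound 1 to compound 3 (0.36 log units; beyond the scatter) lies beyond it.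

Compound 4 `Cc1c(C(=O)/C=C/c2ccc(Br)cc2)[n+]([O-])c2ccccc2[n+]1[O-]` is not yet measured. It differs from compound 3 in one place: bromo in place of methyl on an aromatic carbon.

Within the data shown here, two measured steps bear on this. First, a 4.4-fold lower number from compound 1 to compound 2 (0.64 log units; beyond the scatter) and a 2.3-fold lower number from compound 1 to compound 3 (0.36 log units; beyond the scatter) show that both chloro and methyl give lower numbers than methoxy in this assay. Second, a 1.9-fold higher number from compound 2 to compound 3 (0.28 log units; within the scatter), which swaps the two halogen-like and alkyl groups directly, falls within the scatter. A bromo in place of methyl is therefore expected to move the number little, if anything somewhat downward, in the direction of compound 2. Compound 4 is accordingly expected to give about 22000 nM, with a range from 9000 nM to 50000 nM. This estimate means a step of a 1.8-fold lower number from compound 3 to compound 4 (0.26 log units; within the scatter), which is expected to stay close to the scatter.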

Compound 4, half-maximal cytotoxic concentration: 43000 nM
The estimate for compound 4 lay 2.0-fold (0.29 log units) below the measured number; low and high end bracket the measured number.
By their numbers in this assay, from the lowest: compounds 2, 3 and 4 (each within the scatter of the next, the first and the last beyond it); then compound 1.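

In this assay, the change from 4-methylphenyl to 4-bromophenyl, with a 1.1-fold higher number from compound 3 to compound 4 (0.03 log units; within the scatter), does not separate the two groups at this place on the aromatic ring. The two halogens do separate, though only modestly: a 2.0-fold higher number from compound 2 to compound 4 (0.31 log units; beyond the scatter) is a step beyond the scatter, so bromo and chloro are not interchangeable here. Methoxy also remains apart from bromo, with a 2.1-fold lower number from compound 1 to compound 4 (0.33 log units; beyond the scatter) as another modest step, and compound 1 keeps the highest number of the four, which means more compound is tolerated. Nothing measured here explains why these groups differ or why methyl and bromo match. As far as these compounds go, it also remains open where an amine, a carboxylic acid or a longer chain at this same place would fall relative to methoxy and the other three groups.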